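A Thiazole Amide in Place of a Fluorinated Phenyl Amide

The source may report more compounds than this note shows. Statements on the series, on what has been measured and on what is new or still open speak of the compounds shown alone.

Compound 1, `COc1ccc2nc(C)cc(OC(C)(C)C(=O)Nc3cc(C)cc(C)c3)c2c1`: > 100000 nM
Compound 2, `COc1ccc2nc(C)cc(OC3CCN(c4ccccc4)C3=O)c2c1`: 100000 nM
Compound 3, `COc1ccc2nc(C)cc(OCC(=O)Nc3cc(C)c(F)c(C)c3)c2c1`: > 100000 nM

In a toxicity assay on HepG2 cells (Homo sapiens) for inhibition, read by CellTiter-Glo, with a stated time of 48 h (on this read-out higher numbers stand for weaker inhibition and lower numbers for stronger inhibition), compound 1 reaches only the limit of the assay, > 100000 nM, which is not a measured number. Compound 2 gives 100000 nM. Compound 3 also sits at the limit, > 100000 nM, so it stands where the assay stops reporting a number, and the limit of > 100000 nM in this assay, at which 2 of the 3 values shown sit, shows that this is where most of the values shown lie.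

Compound 4, `COc1ccc2nc(C)cc(OCC(=O)Nc3nc(C)c(C)s3)c2c1`, has not yet been measured. It differs from compound 3 in one place: 4,5-dimethyl-1,3-thiazol-2-yl in place of 4-fluoro-3,5-dimethylphenyl on an amide-type nitrogen. For the measured compounds named here, no step between two measured compounds that differ in a single place is available, so the expected size of this step rests only on where compound 3 stands. The change is expected to make no difference beyond the scatter, in neither direction. Compound 4 is therefore expected to give 100000 nM, within 30000 nM to 100000 nM, most likely again reported as a limit. The step of a number no higher from compound 3 to compound 4 (the limit leaves the size open) is expected to be none beyond the scatter.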

Compound 4, half-maximal inhibitory concentration: > 100000 nM
Compound 4 ended at the assay's limit; the forecaster's own chance of this, stated with the estimate: 75%; the middle value lies on the limit itself.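

In this assay compound 4 gives > 100000 nM, a limit and not a number. For the compounds shown here, compound 3 stands at a limit too, so no step between compound 3 and compound 4 can be read. The compounds shown leave open whether this exchange of groups changes the read-out at all, as most values rest at one point: the limit of > 100000 nM in this assay, at which 3 of the 4 values shown sit.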